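Swapping Bromo for Chloro at One Aromatic Carbon

This account rests on a few compounds, and the source may have more. Where it says the series, first, only, none or still open, it means among the compounds named here.

Of the compounds shown here, three built on a shared core have been tested in an ADME assay on MT4 cells (Homo sapiens) for cytotoxicity, read by MTT assay, with a stated time of 4 days; on this read-out lower numbers stand for higher toxicity in this test and higher numbers for lower toxicity in this test. Compound 1 `O=C(COc1cccc2ccccc12)N/N=C/c1ccccc1Br` gives 11.4 ug/mL. Compound 2 `O=C(COc1cccc2ccccc12)N/N=C/c1ccccc1O` gives 5.19 ug/mL. Compound 3 `O=C(COc1cccc2ccccc12)N/N=C/c1cccc(Br)c1` gives 87.4 ug/mL, the highest number of the three, which means the lowest toxicity in this set.

The next compound, compound 4 `O=C(COc1cccc2ccccc12)N/N=C/c1cccc(Cl)c1`, differs from compound 3 in one place: chloro in place of bromo on an aromatic carbon. This puts chloro in place of bromo on an aromatic carbon, meta to a large group.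

Among the measured compounds shown here, no measured step makes this exact swap, so the evidence is indirect. With 3-bromophenyl in place of 2-bromophenyl, the data show a 7.7-fold higher number from compound 1 to compound 3 (0.88 log units; beyond the scatter), a modest step. With hydroxy in place of bromo, they show a 2.2-fold lower number from compound 1 to compound 2 (0.34 log units; beyond the scatter), also modest. The largest change, a 17-fold higher number from compound 2 to compound 3 (1.23 log units; beyond the scatter), alters both the group and its place on the ring. Each of these steps changes where the group sits, what kind of group it is, or both. The new swap keeps the place and exchanges bromo for chloro, so no step beyond the scatter is expected in this assay.

The expected change is a 1.2-fold lower number from compound 3 to compound 4 (0.07 log units; within the scatter). For compound 4 the estimated value is 75 ug/mL, with an expected range of 30 ug/mL to 170 ug/mL.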

Compound 4, half-maximal cytotoxic concentration: 89.9 ug/mL
The estimate for compound 4 lay 1.2-fold (0.08 log units) below the measured number, and the stated range covers the measured number.
By their numbers in this assay, from the lowest: compound 2; then compound 1; then compounds 3 and 4 (each within the scatter of the next).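

In this assay, the step of a 1.0-fold higher number from compound 3 to compound 4 (0.01 log units; within the scatter) shows that chloro and bromo cannot be told apart on this aromatic carbon, meta to a large group, so the low toxicity of compound 3 in this test does not depend on bromine specifically. The wide gaps to the more toxic compounds remain when chloro is the group present: a 17-fold higher number from compound 2 to compound 4 (1.24 log units; beyond the scatter) in the change from 2-hydroxyphenyl, and a 7.9-fold higher number from compound 1 to compound 4 (0.90 log units; beyond the scatter) in the change from 2-bromophenyl, so the 3-chlorophenyl compound sits with the 3-bromophenyl compound at the high end of this small set. Nothing measured here accounts for why the two groups give matching numbers.

Among the compounds shown here, it remains open whether chloro and bromo would also match when placed as in compound 1, since this exchange has been read at only one place on the ring. As far as these compounds go, it is also open how far this tolerance extends on the same aromatic carbon, for example to a methoxy group, an amine or a carboxylic acid, whose numbers in this assay could differ from those of the two halogens.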